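The compounds below may be only part of what the source reports. "The series", "measured", "known", "first", "only" and "open" are said of these compounds alone.

Measured so far:
Compound 1 `O=S(=O)(c1ccc(Br)cc1)c1nc2ccccc2nc1Nc1ccccc1` gives 1180 nM in a functional assay on PC-3 cells (Homo sapiens) for cytotoxicity, read by MTT assay, with a stated time of 72 h; a lower number here means a stronger inhibitor, a higher number a weaker inhibitor.
Compound 2 `O=S(=O)(c1ccc(Br)cc1)c1nc2ccccc2nc1Nc1ccc(F)cc1` gives 9160 nM in this assay.

Compound 2 stands highest of these two numbers; its nearest neighbour is compound 1, and the step from compound 1 to compound 2 was a 7.8-fold higher number from compound 1 to compound 2 (0.89 log units; beyond the scatter). Compound 3 `O=S(=O)(c1ccc(Br)cc1)c1nc2ccccc2nc1Nc1ccc(C(F)(F)F)cc1` differs from compound 2 by trifluoromethyl in place of fluoro on an aromatic carbon, placed para to a large group on a six-membered aromatic ring of carbon only. Going by the values given here, only one measured step touches this position, and that step, a 7.8-fold higher number from compound 1 to compound 2 (0.89 log units; beyond the scatter), concerns fluoro replacing hydrogen rather than trifluoromethyl replacing fluoro, so it bears on the change only loosely. Among the compounds with values here, no step for trifluoromethyl exists here. A further small rise, or no change beyond the scatter, is therefore expected from compound 2 to compound 3, namely a 1.3-fold higher number from compound 2 to compound 3 (0.12 log units; within the scatter). For compound 3 the estimate in this assay is 12000 nM, between 4000 nM and 40000 nM.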

Compound 3, half-maximal inhibitory concentration: 4150 nM
For compound 3 the middle estimate is 2.9-fold (0.46 log units) above the measured one; the range from low to high includes it.
By their numbers in this assay, from the lowest: compound 1; then compound 3; then compound 2.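

At this position, on an aromatic carbon para to a large group, the change from fluoro to trifluoromethyl gives a 2.2-fold lower number from compound 2 to compound 3 (0.34 log units; beyond the scatter) in this assay and so recovers part of what fluoro lost. Hydrogen still gives the lowest number of the three, with a 3.5-fold higher number from compound 1 to compound 3 (0.55 log units; beyond the scatter) beyond the scatter, so both groups placed here stand above hydrogen, and the larger trifluoromethyl stands closer to it than fluoro does. Nothing available here explains this order.

The compounds shown leave open whether a methyl, a methoxy, an amine or a carboxylic acid at this position would also stand above hydrogen. They also leave open whether this order would hold if the bromine on the other aromatic ring were replaced by chlorine.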